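This account rests on a few compounds, and the source may have more. Where it says the series, first, only, none or still open, it means among the compounds named here.

Measured so far in an assay on CHO cells for displacement of a labelled ligand from 5-hydroxytryptamine receptor 1D (Homo sapiens); a higher number here means a weaker inhibitor, a lower number a stronger inhibitor:
compound 1 `c1ccc(CNCC2CCN(CCCc3c[nH]c4ccc(-n5cnnc5)cc34)CC2)cc1` gives 1.6 nM;
compound 2 `CC(=O)Nc1ccc([C@@H](C)NCC2CCN(CCCc3c[nH]c4ccc(-n5cnnc5)cc34)CC2)cc1` gives 1.5 nM;
compound 3 `C[C@H](NCC1CCN(CCCc2c[nH]c3ccc(-n4cnnc4)cc23)CC1)c1ccccc1` gives 4.4 nM.

Compound 1 and compound 2 lie within the scatter of each other (a 1.1-fold lower number from compound 1 to compound 2 (0.03 log units; within the scatter)), while compound 3 gives a higher number (a 2.8-fold higher number from compound 1 to compound 3 (0.44 log units; beyond the scatter), a 2.9-fold higher number from compound 2 to compound 3 (0.47 log units; beyond the scatter)). Compound 4 `c1cncc(CNC2CCN(CCCc3c[nH]c4ccc(-n5cnnc5)cc34)CC2)c1` differs from compound 1 as follows: ((pyridin-3-yl)methyl)amino in place of (benzylamino)methyl on a saturated ring carbon. Within the data shown here, none of the measured steps touches this place; they only vary the group on the amine nitrogen, where a small change cost a modest step and a larger one cost nothing beyond the scatter. With no direct guide, a modest weakening or none is expected, a 2.5-fold higher number from compound 1 to compound 4 (0.40 log units; beyond the scatter). Compound 4 is therefore estimated at 4 nM, between 1.2 nM and 14 nM, in this assay.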

Compound 4, half-maximal inhibitory concentration: 35 nM
For compound 4 the middle estimate is 8.8-fold (0.94 log units) below the measured one; measured number above the stated range.
By their numbers in this assay, from the lowest: compounds 2 and 1 (each within the scatter of the next); then compound 3; then compound 4.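

Moving to the group on the saturated ring carbon has a far larger effect than the earlier changes on the amine nitrogen: in this assay, ((pyridin-3-yl)methyl)amino in place of (benzylamino)methyl gives a large loss (a 22-fold higher number from compound 1 to compound 4 (1.34 log units; beyond the scatter)). The loss is still clear against the weaker branched compound (an 8.0-fold higher number from compound 3 to compound 4 (0.90 log units; beyond the scatter)). The swap changes both the link to the ring and the aromatic ring, and no measurement here explains the loss. Still open, on these data alone, is which change matters more: benzylamino directly on that ring carbon, or ((pyridin-3-yl)methyl)aminomethyl, would separate them.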